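The source may report more compounds than this note shows. Statements on the series, on what has been measured and on what is new or still open speak of the compounds shown alone.

Measured so far:
compound 1, `O=C(NS(=O)(=O)CCNC(=O)C1CC1)c1ccc(Nc2nc(NC3(c4ccc(Cl)cc4)CC3)nc(OCC(F)(F)F)n2)cc1`, in an ADME assay on microsomes from liver (Rattus norvegicus) for metabolic stability, with a stated time of 10 min; a higher number here means that more of the compound is left, a lower number that less of the compound is left: "not active" (no number reported)
compound 2, `CC(C)OC(=O)NCCS(=O)(=O)NC(=O)c1ccc(Nc2nc(NC3(c4ccc(Cl)cc4)CC3)nc(OCC(F)(F)F)n2)cc1`, in this assay: 73%

For the measured compounds named here, compound 2 stands alone with a number in this assay; compound 1 carries only a qualitative note and no figure, so no step between the two can be sized. The unmeasured compound 3 is `CC(C)(C)CNCCS(=O)(=O)NC(=O)c1ccc(Nc2nc(NC3(c4ccc(Cl)cc4)CC3)nc(OCC(F)(F)F)n2)cc1`. It differs from compound 2 in one place: neopentyl in place of isopropoxycarbonyl on an amine nitrogen whose other neighbour is a saturated chain carbon. Going by the values given here, no measured pair shows what such a swap does here, so the expectation rests on compound 2 alone. A modest fall in the share of compound remaining is expected, of a size near the edge of the usual scatter, a number 13 percentage points lower from compound 2 to compound 3 (beyond the scatter). Compound 3 is therefore estimated at 60%, with a plausible range from 35% to 85%.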

Compound 3, percent of the compound remaining: 90%
Estimate against measurement, compound 3: 30 percentage points below; measured number outside the range, above it.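

In this assay, for the compounds shown here, neopentyl in place of isopropoxycarbonyl on the amine nitrogen gives a number 17 percentage points higher from compound 2 to compound 3 (beyond the scatter) and so provides the first sized step at this position. The group on this nitrogen therefore makes a measurable difference to how much compound is left, and a group of carbon atoms alone, with no carbonyl and no oxygen, is compatible with a large share remaining. Nothing in the data explains the rise, so which part of the swap matters remains unknown.

The compounds shown leave open what an unsubstituted amine, a smaller ethyl group or a group carrying a carboxylic acid would do on this nitrogen. Any step involving compound 1 cannot be read, since it has no number to compare.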